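Piperazine series, cytotoxicity notes: compound 2 to compound 3

The source may report more compounds than this note shows. Statements on the series, on what has been measured and on what is new or still open speak of the compounds shown alone.

Measured so far in a functional assay on cells (Rhabdomyosarcoma cell, Homo sapiens) for cytotoxicity; a lower number here means a stronger inhibitor, a higher number a weaker inhibitor:
compound 1, `Cc1ccccc1C(c1ccccc1)N1CCN(c2ncnc3c2cnn3-c2ccccc2)CC1`: > 25000 nM, a limit of the assay and not a number.
compound 2, `Cc1ccsc1C(c1ccccn1)N1CCN(c2ncnc3c2cnn3-c2ccccc2)CC1`: > 25000 nM, likewise a limit of the assay and not a number.

Compound 2 therefore stands at the limit in this assay, and nothing on the numbers separates it from compound 1; both values sit at the limit of > 25000 nM in this assay, at which 2 of the 2 values shown sit. Among the compounds with values here, no step between measured compounds can be drawn from this, and no ordering between compound 1 and compound 2 is possible.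

Compound 3, `Cc1ccccc1C(c1sccc1C)N1CCN(c2ncnc3c2cnn3-c2ccccc2)CC1`, remains to be measured in this assay. It differs from compound 2 by 2-methylphenyl in place of pyridin-2-yl on a saturated chain carbon bound to an amine nitrogen in a ring and an aromatic carbon; in words, 2-methylphenyl in place of pyridin-2-yl on a saturated chain carbon bound to an amine nitrogen in a ring and an aromatic carbon. Within the data shown here, no measured step for this change exists. With both measured compounds at the limit, the step expected in this assay is a step that the limit leaves unreadable from compound 2 to compound 3, none beyond the scatter, with compound 3 expected most likely to report a limit as well. The estimate for compound 3 in this assay is 30000 nM, with a range from 8000 nM to 100000 nM.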

Compound 3, half-maximal inhibitory concentration: > 25000 nM
Compound 3: no number, only a limit; the forecaster's own chance of this, stated with the estimate: 80%; the middle value is on the limit's open side.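

Compound 3 gives > 25000 nM in this assay, a limit of the assay and not a number. No new step can be read from compound 1 or compound 2 to compound 3, because all three values are limits: the limit of > 25000 nM in this assay, at which 3 of the 3 values shown sit.

The compounds shown leave open how these three rank in this assay, and which change, if any, would bring a compound to a readable number.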